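The source may report more compounds than this note shows. Statements on the series, on what has been measured and on what is new or still open speak of the compounds shown alone.

Compound 2 `O=C(Oc1ccccc1)c1cc([N+](=O)[O-])cc([N+](=O)[O-])c1` gives 15800 nM in an assay on isolated protein (blood) for inhibition of Polyunsaturated fatty acid 5-lipoxygenase (Homo sapiens), read by ELISA, with stated times of 15 min and 30 min (on this read-out higher numbers stand for weaker inhibition and lower numbers for stronger inhibition), the highest of the two numbers recorded, with compound 1 `Cc1cccc(OC(=O)c2cc([N+](=O)[O-])cc([N+](=O)[O-])c2)c1` at 500 nM as its nearest neighbour. Among the measured compounds shown here, the one measured step that bears on the next change is a 32-fold higher number from compound 1 to compound 2 (1.50 log units; beyond the scatter), in which a methyl on an aromatic carbon gave way to hydrogen. Compound 3 `O=C(Oc1cccc(-c2ccccc2)c1)c1cc([N+](=O)[O-])cc([N+](=O)[O-])c1` carries phenyl in place of hydrogen on an aromatic carbon, at the aromatic carbon meta to a large group. A step toward lower numbers is therefore expected, an 11-fold lower number from compound 2 to compound 3 (1.02 log units; beyond the scatter), though its size remains uncertain. Compound 3 is estimated at 1500 nM, within 250 nM to 8000 nM.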

Compound 3, half-maximal inhibitory concentration: 38000 nM
For compound 3 the middle estimate is 25-fold (1.40 log units) below the measured one, and the stated range ends below it.
By their numbers in this assay, from the lowest: compound 1; then compound 2; then compound 3.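

In this assay phenyl at this aromatic carbon does not repeat the gain seen with methyl, giving a weaker result than hydrogen (a 2.4-fold higher number from compound 2 to compound 3 (0.38 log units; beyond the scatter)) and a much weaker one than methyl (a 76-fold higher number from compound 1 to compound 3 (1.88 log units; beyond the scatter)). A substituent here therefore does not lower the number by itself: methyl and phenyl move it in opposite directions from hydrogen. No evidence at hand explains this reversal. The compounds shown leave open how an ethyl, a methoxy, a chlorine or an amine at this carbon would read.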